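The compounds below may be only part of what the source reports. "The series", "measured", "known", "first", "only" and "open" are said of these compounds alone.

Measured compounds:
- compound 1, `CC(=NNC(=S)Nc1cccc([N+](=O)[O-])c1)c1ccccn1`, 140 nM
- compound 2, `CC(=NNC(=S)Nc1cccc(I)c1)c1ccccn1`, 61 nM
- compound 3, `C/C(=N/NC(=S)Nc1ccccc1I)c1ccccn1`, 8.09 nM

The study looks at three measured thiosemicarbazones and one that awaits measurement, all read in a functional assay on T98G cells (Homo sapiens) for cytotoxicity, read by MTT assay, with a stated time of 48 h; a higher number here means a weaker inhibitor, a lower number a stronger inhibitor. Compound 3 gives the lowest number of the three: compound 3 stands at 8.09 nM, where compound 2 stands at 61 nM, and against compound 1 it stands further off still. How the core of compound 3 differs from that of compound 2 is not broken down here; the two share the same atoms, joined differently.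

One change recurs. From compound 2 to compound 1 the change is nitro in place of iodo on an aromatic carbon, and in this assay it made a step of a 2.3-fold higher number from compound 2 to compound 1 (0.36 log units; beyond the scatter). Compound 4, `C/C(=N/NC(=S)Nc1ccccc1[N+](=O)[O-])c1ccccn1`, is still to be measured; it differs from compound 3 by nitro in place of iodo on an aromatic carbon. This is the same kind of change as that from compound 2 to compound 1, not the same: in compound 1 the nitro sits meta to a large group, in compound 4 it sits ortho to a large group.

Resting on the step of a 2.3-fold higher number from compound 2 to compound 1 (0.36 log units; beyond the scatter), compound 4 is expected to show a step of a 2.5-fold higher number from compound 3 to compound 4 (0.39 log units; beyond the scatter) in this assay. The expected value for compound 4 is 20 nM, between 8 nM and 60 nM, the wider span reflecting that the place of the change is not the same as the one measured.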

Compound 4, half-maximal inhibitory concentration: 6.61 nM
Beside the measured number, compound 4's estimate is 3.0-fold (0.48 log units) above it; measured number below the stated range.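

In this assay, putting nitro in place of iodo on the core of compound 3 gave a 1.2-fold lower number from compound 3 to compound 4 (0.09 log units; within the scatter), so the two numbers on this core cannot be told apart and the step seen on the core of compound 2 was not repeated. Carried from one core to the other, the same change therefore did not give the same result, and the two steps differ: the same change on two cores in this assay, a 2.3-fold higher number (0.36 log units; beyond the scatter) from compound 2 to compound 1 and a 1.2-fold lower number (0.09 log units; within the scatter) from compound 3 to compound 4, 2.8-fold (0.45 log units) apart, beyond the scatter of two such steps

Among these compounds, this shows that, in this small series, the size of the step on one core is a poor guide to its size on the other, but it does not show why, since the cores differ in where the group stands, with the nitro of compound 4 ortho to a large group, and each core offers only a single pair of compounds, so nothing here separates the place of the change from any other difference between the cores.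

The compounds shown carry only iodo and nitro at the changed aromatic carbon, so it stays open how an amine, a carboxylic acid or a methoxy group would behave there on either core. All of the numbers also come from this assay, which leaves open whether the same picture would hold in any other cell line or read-out.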